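The compounds below may be only part of what the source reports. "The series", "measured", "known", "first", "only" and "open" are said of these compounds alone.

Compound 1 `CSc1ccc(NC(=O)Nc2cc(C)nc3ccccc23)cc1` is a urea that links a phenyl ring bearing a methylsulfanyl group to the shared core. In an ADME assay on BJ cells (Homo sapiens) for cytotoxicity, with a stated time of 72 h (on this read-out lower numbers stand for an effect already at smaller amounts and higher numbers for an effect only at larger amounts of compound), compound 1 gives > 25000 nM, which is a limit of the assay and not a measured number. Compound 2 `Cc1cc(NC(=O)Nc2cc(F)cc(F)c2)c2ccccc2n1` carries two fluorines on its phenyl ring instead; in this assay compound 2 gives > 25000 nM, again only a limit. Compound 3 `COC(=O)c1cccc(NC(=O)Nc2cc(C)nc3ccccc23)c1` carries a methyl ester on its phenyl ring, and in this assay compound 3 gives 21000 nM, a number that sits close to where the other two stop. Compound 1 therefore stands at the limit of > 25000 nM in this assay, at which 2 of the 3 values shown sit, with compound 3 a near neighbour; none of the three shows cytotoxicity at small amounts.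

Compound 4 `Cc1cc(NC(=O)Nc2ccc(Cl)cc2)c2ccccc2n1` differs from compound 1 by chloro in place of methylsulfanyl on an aromatic carbon. Among the measured compounds shown here, no step between two measured compounds is available to say how such a swap on this phenyl ring shifts the read-out, and every measured analogue here ends at or near the same ceiling. The step from compound 1 to compound 4 is therefore expected to be a number no higher from compound 1 to compound 4 (the limit leaves the size open), nothing beyond the usual scatter. Compound 4 is expected to give 25000 nM, with a likely range from 12000 nM to 50000 nM, and most probably to be reported again only as a limit.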

Compound 4, half-maximal effective concentration: > 25000 nM
Compound 4: only a limit was reported; the forecaster's own chance of this, stated with the estimate: 75%; the middle value sits exactly at the limit.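

Compound 1 and compound 4 both end at a limit of the assay rather than at a measured number, so no step can be read for chloro in place of methylsulfanyl. The compounds shown leave open whether these two groups differ at all in this assay, where most values stop at the same point: the limit of > 25000 nM in this assay, at which 3 of the 4 values shown sit.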